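This account rests on a few compounds, and the source may have more. Where it says the series, first, only, none or still open, it means among the compounds named here.

Measured so far in an ADME assay on S9 fraction from liver (Rattus norvegicus) for metabolic stability, with a stated time of 1 h; on this read-out lower numbers stand for a less stable compound and higher numbers for a more stable compound:
Compound 1 `N#Cc1cnc(NCc2cnccc2C(F)(F)F)cc1N[C@H]1CC[C@H](O)CC1`: 25%
Compound 2 `N#Cc1cnc(NCc2cnccc2C(F)(F)F)cc1NC1CCOCC1`: 17%

In this assay, among the measured compounds shown here, compound 2 gives 17%, and its only neighbour on these numbers is compound 1 at 25%. The two values lie within the usual scatter of each other, so they do not rank the pair.

Compound 3 `CNC(=O)[C@H]1CC[C@@H](Nc2cc(NCc3cnccc3C(F)(F)F)ncc2C#N)CC1` keeps the shared core and carries 4-(methylcarbamoyl)cyclohexyl in place of oxan-4-yl on a nitrogen on an aromatic ring. For the measured compounds named here, only one measured step bears on this place, the exchange of 4-hydroxycyclohexyl for oxan-4-yl, which gave a number 8 percentage points lower from compound 1 to compound 2 (within the scatter). Going by the values given here, that single step says little about a group as different as the new amide, and no measured compound carries it. Among the compounds with values here, with this one small step as the only guide, no change beyond the scatter is expected, though the uncertainty remains wide. The expected step is a number 7 percentage points higher from compound 2 to compound 3 (within the scatter). For compound 3 the estimated value is 24%, with an expected range of 10% to 42%.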

Compound 3, percent of the compound remaining: 53%
Beside the measured number, compound 3's estimate is 29 percentage points below it, and the stated range ends below it.
By their numbers in this assay, from the lowest: compounds 2 and 1 (each within the scatter of the next); then compound 3.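

In this assay, the place on a nitrogen on an aromatic ring proves able to shift the read-out beyond the scatter: 4-(methylcarbamoyl)cyclohexyl in place of oxan-4-yl gives a number 36 percentage points higher from compound 2 to compound 3 (beyond the scatter) and, in place of 4-hydroxycyclohexyl, gives a number 28 percentage points higher from compound 1 to compound 3 (beyond the scatter) as well. Among the compounds shown here, the only earlier exchange at this place, oxan-4-yl for 4-hydroxycyclohexyl, gave a number 8 percentage points lower from compound 1 to compound 2 (within the scatter) and so could not show that the group here matters; compound 3 now stands clear of both earlier compounds, whichever of them it is set against. Nothing at hand accounts for the rise, so it stands as an observation on these three compounds alone.

The compounds shown do not separate the contribution of the methylcarbamoyl group from that of the carbon-only ring, since no compound carries the cyclohexyl ring with a carboxylic acid, a primary amide, a dimethylamide or an amine in that spot. They also leave open whether the opposite arrangement at the two defined stereocentres of 4-(methylcarbamoyl)cyclohexyl, or a longer chain between the ring and the amide, would keep the gain.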